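Chloro for fluoro on the 2-fluorophenyl analogue

The source may report more compounds than this note shows. Statements on the series, on what has been measured and on what is new or still open speak of the compounds shown alone.

In a functional assay on SW-620 cells (Homo sapiens) for cytotoxicity, read by MTT assay, with stated times of 4 h and 72 h, tested at 2 uM (on this read-out higher numbers stand for weaker inhibition and lower numbers for stronger inhibition), compound 1 (`Cc1cc(Nc2ccc(C(=O)/C=C/c3ccc(F)cc3)cc2)n2nc(SCc3nc4ccccc4[nH]3)nc2n1`) gives 85 nM, compound 2 (`COc1ccc(/C=C/C(=O)c2ccc(Nc3cc(C)nc4nc(SCc5nc6ccccc6[nH]5)nn34)cc2)cc1`) gives 170 nM and compound 3 (`Cc1cc(Nc2ccc(C(=O)/C=C/c3ccccc3F)cc2)n2nc(SCc3nc4ccccc4[nH]3)nc2n1`) gives 250 nM. Compound 3 stands within the scatter of compound 2 but apart from compound 1. The only separation beyond the scatter is a 2.9-fold higher number from compound 1 to compound 3 (0.47 log units; beyond the scatter), with 2-fluorophenyl in place of 4-fluorophenyl. The other two pairs do not separate: a 2.0-fold higher number from compound 1 to compound 2 (0.30 log units; within the scatter) and a 1.5-fold higher number from compound 2 to compound 3 (0.17 log units; within the scatter).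

Compound 4 (`Cc1cc(Nc2ccc(C(=O)/C=C/c3ccccc3Cl)cc2)n2nc(SCc3nc4ccccc4[nH]3)nc2n1`) differs from compound 3 by chloro in place of fluoro on an aromatic carbon, ortho to a large group. Within the data shown here, no measured pair makes this exchange, so the evidence is indirect. Among these three analogues, changes on this aromatic ring have moved the number by no more than a 2.9-fold higher number from compound 1 to compound 3 (0.47 log units; beyond the scatter). No step beyond the scatter is therefore expected in this assay. The expected change is a 1.1-fold lower number from compound 3 to compound 4 (0.06 log units; within the scatter). Compound 4 is estimated at 220 nM, with an expected range of 100 nM to 500 nM.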

Compound 4, half-maximal inhibitory concentration: 680 nM
The estimate for compound 4 lay 3.1-fold (0.49 log units) below the measured number; the measured number lies above the stated range.
By their numbers in this assay, from the lowest: compounds 1, 2 and 3 (each within the scatter of the next, the first and the last beyond it); then compound 4.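

In this assay, among these compounds, the exchange of one halogen for another at this place, ortho to a large group, gives a step beyond the scatter, a 2.7-fold higher number from compound 3 to compound 4 (0.43 log units; beyond the scatter) and so the identity of the halogen matters here, which the earlier compounds could not show because none of them held an exchange at this place. Among the compounds shown here, compound 4 also separates from the other two analogues, with a 4.0-fold higher number from compound 2 to compound 4 (0.60 log units; beyond the scatter) and an 8.0-fold higher number from compound 1 to compound 4 (0.90 log units; beyond the scatter) making it the weakest of the four, the only compound beyond the scatter of all the others. No measurement at hand accounts for the step from fluoro to chloro.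

Open, going by these compounds, is whether a bromo or a methyl group at this place would lie nearer compound 3 or compound 4. Also open, on these data alone, is whether a 4-chlorophenyl group would stand as far from compound 1 as chloro stands from fluoro here.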